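The source may report more compounds than this note shows. Statements on the series, on what has been measured and on what is new or still open speak of the compounds shown alone.

In an in vitro functional assay on HEK293 cells for antagonist activity at melanin-concentrating hormone receptor 1 (Homo sapiens), read by GTPgammaS binding, with a stated time of 45 min (on this read-out higher numbers stand for weaker inhibition and lower numbers for stronger inhibition), compound 2 `CC(=O)OCC(C)(C)NC(=O)N(CCC1CCN(Cc2ccc(C)cc2)CC1)Cc1ccc(-c2ccc(F)cc2)cc1` gives 409 nM. Compound 1 `COc1ccc(-c2ccc(CN(CCC3CCN(Cc4ccc(C)cc4)CC3)C(=O)NC(C)C)cc2)cc1` gives 467 nM in this assay, a number within the usual scatter of that of compound 2. Compound 3 `COc1ccc(-c2ccc(CN(CCC3CCN(Cc4ccc(C)cc4)CC3)C(=O)NC(C)(C)COC(C)=O)cc2)cc1` carries methoxy in place of fluoro on an aromatic carbon, methoxy in place of fluoro on an aromatic carbon. Among the compounds with values here, no measured pair shows this change alone, so its size is open. Since compound 1 with the same methoxy group reached 467 nM, compound 3 is expected to change little, with a step of a 1.0-fold higher number from compound 2 to compound 3 (0.01 log units; within the scatter), not beyond the scatter. Compound 3 is therefore estimated at 420 nM, within a range from 180 nM to 950 nM.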

Compound 3, antagonist equilibrium constant: 647 nM
Estimate against measurement, compound 3: 1.5-fold (0.19 log units) below, and the stated range covers the measured number.
By their numbers in this assay, from the lowest: compounds 2, 1 and 3 (each within the scatter of the next).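

In this assay, methoxy in place of fluoro on the aromatic carbon gives a 1.6-fold higher number from compound 2 to compound 3 (0.20 log units; within the scatter), so 4-fluorophenyl and 4-methoxyphenyl cannot be told apart at this position. Acetoxymethyl in place of hydrogen on the saturated chain carbon, with 4-methoxyphenyl present, gives a 1.4-fold higher number from compound 1 to compound 3 (0.14 log units; within the scatter), so that change cannot be told apart from the scatter either. Nothing available explains either step. As far as these compounds go, whether an amine or a carboxylic acid on that aromatic carbon would give a step beyond the scatter remains open. So does the outcome of a longer chain in place of acetoxymethyl.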